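Chain Length Between Core and Methylpiperazine: Compound 4

This account rests on a few compounds, and the source may have more. Where it says the series, first, only, none or still open, it means among the compounds named here.

Compound 1 `CN1CCN(CCCCCn2c3c(c4ccccc42)C(=O)c2c[n+]([O-])c4ccccc4c2C3=O)CC1`: 830 nM
Compound 2 `O=C1c2c[n+]([O-])c3ccccc3c2C(=O)c2[nH]c3ccccc3c21`: 1380 nM
Compound 3 `CN1CCN(CCCn2c3c(c4ccccc42)C(=O)c2c[n+]([O-])c4ccccc4c2C3=O)CC1`: 560 nM

In a functional assay on SH-SY5Y cells (Homo sapiens) for cytotoxicity, read by MTT assay, with a stated time of 72 h (on this read-out higher numbers stand for weaker inhibition and lower numbers for stronger inhibition), compound 3 has the lowest of the three numbers, though its gap to compound 1, a 1.5-fold lower number from compound 1 to compound 3 (0.17 log units; within the scatter), is within the scatter; only a 2.5-fold lower number from compound 2 to compound 3 (0.39 log units; beyond the scatter) stands beyond it. Compound 4 `CN1CCN(CCCCn2c3c(c4ccccc42)C(=O)c2c[n+]([O-])c4ccccc4c2C3=O)CC1` differs from compound 3 by (4-methylpiperazin-1-yl)methyl in place of 4-methylpiperazin-1-yl on a saturated chain carbon, three bonds along the chain from an aromatic nitrogen. The two steps that bear on it are a 1.5-fold lower number from compound 1 to compound 3 (0.17 log units; within the scatter) and a 2.5-fold lower number from compound 2 to compound 3 (0.39 log units; beyond the scatter); the first, a change of chain length alone, is small, and the second shows that having a chain at all matters more than its length. Compound 4 sits between compound 3 and compound 1 in chain length, so the step of a 1.2-fold higher number from compound 3 to compound 4 (0.06 log units; within the scatter) is expected to stay within the scatter. Compound 4 is estimated to give 650 nM, with a range from 350 nM to 1200 nM.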

Compound 4, half-maximal inhibitory concentration: 100 nM
Beside the measured number, compound 4's estimate is 6.5-fold (0.81 log units) above it; measured number below the stated range.
By their numbers in this assay, from the lowest: compound 4; then compounds 3, 1 and 2 (each within the scatter of the next, the first and the last beyond it).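

In this assay, the butyl chain stands apart from both its neighbours, with a 5.6-fold lower number from compound 3 to compound 4 (0.75 log units; beyond the scatter) and an 8.3-fold lower number from compound 1 to compound 4 (0.92 log units; beyond the scatter) on either side of it. The response to chain length at this aromatic nitrogen is therefore a sharp optimum among these compounds rather than a steady trend, which the close numbers of the propyl and pentyl chains had hidden. Adding the butyl chain to the bare nitrogen gives a 14-fold lower number from compound 2 to compound 4 (1.14 log units; beyond the scatter) in the largest step of the set.

No measured evidence explains why this chain length stands out. The compounds shown also leave open how an ethyl or hexyl chain, or a morpholine on the butyl chain, would behave.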